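Swapping the naphthyl attachment point on the triazole core

A few compounds are considered here, and "the series" means these few. Any claim that something is new, unique, unknown or untested is made for them only; others in the source may bear on it.

Measured compounds in a functional assay on MDA-MB-231 cells (Homo sapiens) for antiproliferative activity, with a stated time of 5 days; a lower number here means a stronger inhibitor, a higher number a weaker inhibitor:
- compound 1 `O=C1C=CC2(C=C1)OCC(=O)N2c1nc(-c2ccc3ccccc3c2)nn1-c1ccc2ccccc2c1` gives 50 nM
- compound 2 `O=C1C=CC2(C=C1)OCC(=O)N2c1nc(-c2cccc3ccccc23)nn1-c1ccccc1` gives 50 nM
- compound 3 `Cc1ccc(-n2nc(-c3ccc4ccccc4c3)nc2N2C(=O)COC23C=CC(=O)C=C3)cc1` gives 30 nM

Compound 3 shows the lowest number of the three, yet compound 1 and compound 2 both sit within the usual scatter of it, so no ranking among them can be claimed. For the measured compounds named here, the one single-point change measured so far, a 1.7-fold lower number from compound 1 to compound 3 (0.22 log units; within the scatter), concerns the group on the aromatic nitrogen and stays within the scatter.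

Compound 4 `Cc1ccc(-n2nc(-c3cccc4ccccc34)nc2N2C(=O)COC23C=CC(=O)C=C3)cc1` is the next compound to be tested. It differs from compound 3 only in where the naphthyl group is joined: naphthalen-1-yl in place of naphthalen-2-yl on an aromatic carbon. Going by the values given here, no measured step addresses this carbon-bound group directly. Compound 1 and compound 2 carry the two alternative naphthyl groups at that carbon, but they also differ on the nitrogen, so their equal values only hint that the attachment point matters little. On that basis the expected change is a 1.2-fold higher number from compound 3 to compound 4 (0.07 log units; within the scatter), a step not expected to exceed the scatter. Compound 4 is therefore estimated at 35 nM, with a likely range from 15 nM to 80 nM.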

Compound 4, half-maximal inhibitory concentration: 40 nM
For compound 4 the middle estimate is 1.1-fold (0.06 log units) below the measured one; low and high end bracket the measured number.
By their numbers in this assay, from the lowest: compounds 3, 4, 1 and 2 (each within the scatter of the next).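

In this assay, the step at this carbon with everything else held fixed is a 1.3-fold higher number from compound 3 to compound 4 (0.12 log units; within the scatter) for naphthalen-1-yl in place of naphthalen-2-yl, so with the 4-methylphenyl group kept on the nitrogen, the point where the naphthyl group is joined has no effect that can be told from the scatter. The new compound also gives a second clean comparison, on the group at the ring nitrogen: methyl in place of hydrogen on an aromatic carbon gives a 1.3-fold lower number from compound 2 to compound 4 (0.10 log units; within the scatter) and also stays within the scatter, so this small addition does not separate the two compounds either. No accompanying measurement offers an explanation for these small steps.

As far as these compounds go, all four compounds carry a naphthyl group at this carbon, so it remains open whether the same flat picture would hold with a pyridine ring, an amine or a carboxylic acid there. From the compounds shown here alone, it is equally open what a longer chain on the nitrogen, in place of the aromatic groups seen so far, would do to the number in this assay.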